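Methoxy for Trifluoromethyl on a Dopamine Receptor Ligand

The source may hold more compounds than are shown below. What is called first, only, known or untested is meant among the compounds shown, and "the series" means these compounds.

Compound 1 `O=C(NC1CCN(Cc2cccc(Br)c2)CC1)c1cccc2ccccc12` gives 66 nM in an assay on isolated protein for displacement of a labelled ligand from D(4) dopamine receptor (Homo sapiens); on this read-out higher numbers stand for weaker inhibition and lower numbers for stronger inhibition.
Compound 2 `O=C(NC1CCN(Cc2ccc(C(F)(F)F)cc2)CC1)c1cccc2ccccc12` gives 96 nM in this assay.

Among the measured compounds shown here, only two compounds have been measured so far, and they share one core, an amide linking a naphthalene to a piperidine whose nitrogen carries a substituted benzyl group. For the measured compounds named here, the single step between them, a 1.5-fold higher number from compound 1 to compound 2 (0.16 log units; within the scatter), exchanged one substituted phenyl for another on the saturated chain carbon bound to the amine nitrogen in the ring. Compound 2 therefore sits alongside compound 1, the two numbers lying within the scatter of each other, so neither can be called stronger or weaker.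

Compound 3 `COc1ccc(CN2CCC(NC(=O)c3cccc4ccccc34)CC2)cc1` differs from compound 2 by methoxy in place of trifluoromethyl on an aromatic carbon. Going by the values given here, no measured step exchanges these two groups, so the expectation rests on the only comparison available: that step, a 1.5-fold higher number from compound 1 to compound 2 (0.16 log units; within the scatter), altered a phenyl substituent and stayed within the scatter. On that basis compound 3 is expected to give a number close to that of compound 2, with the step of a 1.1-fold lower number from compound 2 to compound 3 (0.05 log units; within the scatter) not expected to exceed the scatter. The estimate for compound 3 in this assay is 85 nM, with a range from 30 nM to 250 nM.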

Compound 3, inhibition constant: 223 nM
For compound 3 the middle estimate is 2.6-fold (0.42 log units) below the measured one; the range from low to high includes it.
By their numbers in this assay, from the lowest: compounds 1 and 2 (each within the scatter of the next); then compound 3.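

In this assay the group on this aromatic carbon, para to a large group, makes a readable difference: methoxy in place of trifluoromethyl gives a 2.3-fold higher number from compound 2 to compound 3 (0.37 log units; beyond the scatter) and so weakens inhibition, modestly but beyond the scatter. The wider exchange, 4-methoxyphenyl in place of 3-bromophenyl, gives a 3.4-fold higher number from compound 1 to compound 3 (0.53 log units; beyond the scatter) and is also modest, which leaves compound 3 as the weakest of the three while compound 1 and compound 2 stay within the scatter of each other. The earlier step alone could have suggested that the substituent on this phenyl hardly matters, but these three compounds show that at least one exchange on it moves the number beyond the scatter, and nothing available explains why this exchange does so.

From the compounds shown here alone, it remains open whether the change follows the oxygen of the methoxy group or the group as a whole, a question that a hydroxyl, an ethoxy or a plain methyl on the same aromatic carbon could help to settle. Going by these compounds, it is also open whether methoxy in place of trifluoromethyl gives a step of similar size on any other core.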